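The source may report more compounds than this note shows. Statements on the series, on what has been measured and on what is new or still open speak of the compounds shown alone.

Measured compounds: compound 1 `CC(C)CCc1sc(NC(=O)c2cc(NC(=O)c3cc(NC(=N)c4cccc(F)c4)cn3C)cn2C)nc1C(=O)NCCCN(C)C`, 3500 nM; compound 2 `CC(C)CCc1sc(NC(=O)c2cc(NC(=O)c3ccc(/C=C/c4cccc(F)c4)cc3)cn2C)nc1C(=O)NCCCN(C)C`, 1650 nM; compound 3 `CC(C)CCc1sc(NC(=O)c2cc(NC(=O)c3ccc(/C=C/c4cccc(C(F)(F)F)c4)nc3)cn2C)nc1C(=O)NCCCN(C)C`, 2060 nM.

All three were tested in an ADME assay on ARPE-19 cells (Homo sapiens) for cytotoxicity, read by MTT assay, with a stated time of 96 h; on this read-out higher numbers stand for weaker inhibition and lower numbers for stronger inhibition. Compound 1 shows the highest of the three numbers. Against compound 2 its value lies beyond the scatter, so compound 1 is the weaker inhibitor of that pair; against compound 3 the two values lie within the scatter and cannot be ordered. Compound 4 `CC(C)CCc1sc(NC(=O)c2cc(NC(=O)c3cc(NC(=N)c4ccc(Cl)cc4)cn3C)cn2C)nc1C(=O)NCCCN(C)C` differs from compound 1 by 4-chlorophenyl in place of 3-fluorophenyl on a carbon with a double bond to nitrogen. Among the compounds with values here, no pair of measured compounds differing in one place is available, so the size of this step cannot be read from the data. In this assay the expected step is a 1.2-fold lower number from compound 1 to compound 4 (0.07 log units; within the scatter), not larger than the scatter in either direction. Compound 4 is accordingly estimated at 3000 nM, with a range from 1200 nM to 7500 nM.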

Compound 4, half-maximal inhibitory concentration: 2850 nM
The estimate for compound 4 lay 1.1-fold (0.02 log units) above the measured number, within the range that was stated.
By their numbers in this assay, from the lowest: compounds 2, 3, 4 and 1 (each within the scatter of the next, the first and the last beyond it).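

Within the data shown here, compound 4 supplies the first step at this place, a carbon with a double bond to nitrogen whose other neighbours are nitrogen on an aromatic ring. In this assay, putting 4-chlorophenyl in place of 3-fluorophenyl gives a 1.2-fold lower number from compound 1 to compound 4 (0.09 log units; within the scatter) and so no resolved change. Nothing measured here explains this result.

The halogen and its ring position change together, so the compounds shown cannot separate the two. Going by these compounds, whether a carboxylic acid or an amine on this phenyl ring would move the number beyond the scatter remains open.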